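The source may report more compounds than this note shows. Statements on the series, on what has been measured and on what is new or still open speak of the compounds shown alone.

Compounds measured so far:

- Compound 1, `COC(=O)C(=O)Nc1cccc(C(=O)/C=C/c2ccc(O)c(OC)c2)c1`: 43%
- Compound 2, `CCOC(=O)C(=O)Nc1cccc(C(=O)/C=C/c2ccc(O)c(OC)c2)c1`: 66%
- Compound 3, `COc1cc(/C=C/C(=O)c2cccc(NC(=O)c3c(Cl)cccc3Cl)c2)ccc1O`: 99%

In a functional assay on HUVEC cells (Homo sapiens) for inhibition, tested at 10 ug/mL (on this read-out lower numbers stand for a weaker effect and higher numbers for a stronger effect at the one concentration tested), compound 3 gives the highest of the three numbers; the step of a number 33 percentage points higher from compound 2 to compound 3 (beyond the scatter) and the step of a number 56 percentage points higher from compound 1 to compound 3 (beyond the scatter) both lie beyond the scatter, so compound 3 stands clearly above compounds 1 and 2 in this assay. The smaller step of a number 23 percentage points higher from compound 1 to compound 2 (beyond the scatter) separates the two esters.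

Compound 4, `COc1cc(/C=C/C(=O)c2cccc(NC(=O)c3ccc(Cl)cc3Cl)c2)ccc1O`, is the next step from compound 3:

2,4-dichlorophenyl in place of 2,6-dichlorophenyl on a carbonyl carbon

Among the compounds with values here, none of the measured steps bears directly on this change: all three of them swap the whole group on the carbonyl carbon, and no measured pair moves chlorine within a dichlorophenyl ring. What is known is only that the dichlorophenyl amide, compound 3, sits at the top of the range in this assay, which leaves little room upward. The expected step in this assay is a number 9 percentage points lower from compound 3 to compound 4 (within the scatter), within or at the edge of the scatter, and for compound 4 the estimate is 90% with a range from 70% to 100%.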

Compound 4, a percentage reported as inhibition, at one concentration (the size of the read-out at that concentration, not a potency): 70%
The estimate for compound 4 lay 20 percentage points above the measured number; the range from low to high includes it.
By their numbers in this assay, from the lowest: compound 1; then compounds 2 and 4 (each within the scatter of the next); then compound 3.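

In this assay the chlorine pattern on the ring matters, since an exchange that keeps the same atoms but joins them differently, 2,4-dichlorophenyl for 2,6-dichlorophenyl on a carbonyl carbon, gives a step beyond the scatter (a number 29 percentage points lower from compound 3 to compound 4 (beyond the scatter)). The high reading of compound 3 therefore cannot be credited to a dichlorophenyl amide as such: the 2,4-dichlorophenyl group cannot be separated from ethoxycarbonyl (a number 4 percentage points higher from compound 2 to compound 4 (within the scatter)), yet it remains distinct from methoxycarbonyl (a number 27 percentage points higher from compound 1 to compound 4 (beyond the scatter)). Nothing shown accounts for the difference between the two chlorine patterns.

Open, from the compounds shown here alone, is how an unsubstituted phenyl or a 2-chlorophenyl on this carbonyl carbon would compare with compound 3 and compound 4, and so which chlorine carries the gap. Also open, going by these compounds, is whether that gap persists at other concentrations.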